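Swapping chloro for trifluoromethoxy on compound 3

The compounds below may be only part of what the source reports. "The series", "measured", "known", "first", "only" and "open" are said of these compounds alone.

In a functional assay on KB cells (Homo sapiens) for inhibition, read by MTT assay, with a stated time of 24 h, tested at 0.1 ug/mL (a lower number here means less inhibition of growth, a higher number more inhibition of growth at the concentration tested), compound 3 (`O=C(CCCCC(S)CCS)Nc1ccc(Cl)cc1`) gives 9.11% of inhibition at the single concentration tested. For the measured compounds named here, only one other compound offers a number for comparison. Compound 1 (`O=C(CCCCC1CCSS1)Nc1ccc(OC(F)(F)F)cc1`) gives 1.97% in this assay as well, and these two readings lie within the usual scatter of each other, so neither can be ranked over the other. Compound 2 (`O=C(CCCCC1CCSS1)Nc1ccc(Cl)cn1`) was reported as "not active" (no number reported) and has no number to set beside them.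

Compound 4 (`O=C(CCCCC(S)CCS)Nc1ccc(OC(F)(F)F)cc1`) matches compound 3 except at one place. It has trifluoromethoxy in place of chloro on an aromatic carbon, para to a large group (trifluoromethoxy in place of chloro on an aromatic carbon). Going by the values given here, no measured pair here isolates this swap, so the data do not show directly what it does. The nearest clue is compound 1, which also carries trifluoromethoxy and reads 1.97% in this assay and so offers no sign of a large rise. The expected change in this assay is small and downward (a number 3.1 percentage points lower from compound 3 to compound 4 (within the scatter)) and stays within the usual scatter. For compound 4 the estimated value is 6% with an expected range from 0% to 17% in this test.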

Compound 4, percent growth inhibition at one concentration: 7.27%
Beside the measured number, compound 4's estimate is 1.3 percentage points below it; low and high end bracket the measured number.
By their numbers in this assay, from the lowest: compounds 1, 4 and 3 (each within the scatter of the next).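

The swap of trifluoromethoxy for chloro on an aromatic carbon, para to a large group, can now be read directly: in this assay it gives a number 1.8 percentage points lower from compound 3 to compound 4 (within the scatter). So at this position, a group of 5 heavy atoms in place of a single chlorine does not produce a change that can be told apart from repeat-to-repeat variation at the one concentration tested. Compound 4 also forms a pair with compound 1, isolating the open chain against the five-membered non-aromatic ring with 2 hetero atoms while trifluoromethoxy stays in place, and this change gives a number 5.3 percentage points higher from compound 1 to compound 4 (within the scatter), so this comparison does not separate the open and ring forms either; no measurement at hand offers an explanation for either reading.

On these data alone, whether a different group at this aromatic position, such as an amine, a carboxylic acid or a nitrile, would move the reading beyond the scatter remains open. The single concentration also leaves open whether these pairs would separate at other concentrations, where a full dose-response comparison could reveal differences hidden here.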